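Dichloro to monochloro on the fused core: expected cytotoxicity

The source may hold more compounds than are shown below. What is called first, only, known or untested is meant among the compounds shown, and "the series" means these compounds.

Going by the values given here, compound 2 `ClCc1ccccc1Cn1cnc2c(Cl)nc(Cl)nc21` is the only entry with a number in a functional assay on SNB-75 cells (Homo sapiens) for cytotoxicity, read by sulforhodamine B assay, with a stated time of 48 h; on this read-out lower numbers stand for stronger inhibition of growth and higher numbers for weaker inhibition of growth: compound 2 gives 1540 nM. Among the compounds with values here, compound 1 `ClCc1ccc(Cn2cnc3c(Cl)ncnc32)cc1` belongs to the same series, but in this assay compound 1 gives "not determined" (no result reported), so no step between measured compounds can be drawn. Compound 3 `ClCc1ccccc1Cn1cnc2c(Cl)ncnc21` differs from compound 2 by hydrogen in place of chloro on an aromatic carbon, between two ring nitrogen atoms. Within the data shown here, with no measured step to lean on, the expected change is small, toward weaker growth inhibition if any, and within or near the scatter. Compound 3 is therefore estimated at 2500 nM, with a range of 800 nM to 8000 nM. The estimated step is a 1.6-fold higher number from compound 2 to compound 3 (0.21 log units; within the scatter), modest and toward weaker growth inhibition.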

Compound 3, concentration for 50% growth inhibition: 2880 nM
Estimate against measurement, compound 3: 1.2-fold (0.06 log units) below, and the stated range covers the measured number.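

Hydrogen in place of chloro on the aromatic carbon between two ring nitrogen atoms gives a 1.9-fold higher number from compound 2 to compound 3 (0.27 log units; within the scatter) in this assay. Going by these compounds alone, this position therefore keeps growth inhibition in the same range without that chloro, the first such reading. No available evidence accounts for the step.

With compound 1 at "not determined" (no result reported), any step to it cannot be read. As far as these compounds go, how an amine, a methoxy group or a longer alkyl chain at this position would read remains open.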